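The source may hold more compounds than are shown below. What is called first, only, known or untested is meant among the compounds shown, and "the series" means these compounds.

Two measured compounds share the same core and are compared here on a single read-out. Compound 1 `N/C(=N\NC(=S)N1CCCCCC1)c1ccccn1` gives, in a functional assay on A-431 cells (Homo sapiens) for cytotoxicity, read by MTT assay, with a stated time of 72 h, tested at 10 uM (on this read-out higher numbers stand for more inhibition of growth at the one concentration tested and lower numbers for less inhibition of growth), a value of 67%. Compound 2 `N/C(=N\NC(=S)N1CCOCC1)c1ccccn1` gives in this assay a value of 69.4%. Compound 1 thus sits at the bottom of this pair of numbers, a position that carries no weight since its distance to compound 2 lies within the scatter, and the two cannot be told apart. Compound 3 `Cc1ccnc(/C(N)=N/NC(=S)N2CCCCCC2)c1` has not yet been measured in this assay. It differs from compound 1 by methyl in place of hydrogen on an aromatic carbon. For the measured compounds named here, no pair of measured compounds shows what such a change does on this core, so the step in this assay is expected to be small, most likely none beyond the scatter in either direction. On that basis the step of a number 2 percentage points lower from compound 1 to compound 3 (within the scatter) is expected. Compound 3 is accordingly estimated at 65%, with a likely range from 50% to 80%.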

Compound 3, percent growth inhibition at one concentration: 55.5%
Compound 3: the middle estimate sits 9.5 percentage points above what was measured, and the stated range covers the measured number.
By their numbers in this assay, from the lowest: compound 3; then compounds 1 and 2 (each within the scatter of the next).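

Methyl in place of hydrogen on an aromatic carbon, opposite the ring nitrogen, is not a silent change in this assay: it gives a number 11.5 percentage points lower from compound 1 to compound 3 (beyond the scatter), a modest step but the only one here that stands clear of the scatter. For the compounds shown here, the earlier compounds differed only away from this aromatic ring and could not be told apart, so this result is the first sign that this position responds to substitution, and methyl alone is enough to lessen growth inhibition at the one concentration tested. No measurement available here explains this step.

The compounds shown leave open whether ethyl, methoxy or an amine at this position would lower the number further or restore it. They also leave open whether methyl has the same effect on the core of compound 2, or at other carbons of this ring.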